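Dimethylamino to Diethylamino: An Expected Small Step

This account rests on a few compounds, and the source may have more. Where it says the series, first, only, none or still open, it means among the compounds named here.

Measured compounds:
Compound 1 `Cc1cc(N(C)C)nc2ccc(NC(=O)/C=C/c3ccco3)cc12`: 4200 nM
Compound 2 `O=C(/C=C/c1ccco1)Nc1cccc2ncccc12`: > 50000 nM

For the measured compounds named here, in an assay on cells for inhibition of TP53-binding protein 1 (Homo sapiens), read by AlphaScreen, with a stated time of 30 min (on this read-out lower numbers stand for stronger inhibition and higher numbers for weaker inhibition), compound 1 gives 4200 nM, the only true number among the measured compounds. Compound 2 reaches only (the limit of > 50000 nM in this assay, at which 1 of the 2 values shown sits), a limit rather than a number. Compound 3 `CCN(CC)c1cc(C)c2cc(NC(=O)/C=C/c3ccco3)ccc2n1` differs from compound 1 by diethylamino in place of dimethylamino on an aromatic carbon. Going by the values given here, no measured pair shows this kind of change, so a step no larger than the usual scatter is expected, in either direction. Compound 3 is therefore estimated at 4500 nM, between 1500 nM and 14000 nM, which means an expected 1.1-fold higher number from compound 1 to compound 3 (0.03 log units; within the scatter).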

Compound 3, half-maximal inhibitory concentration: 1690 nM
Compound 3: the middle estimate sits 2.7-fold (0.43 log units) above what was measured; low and high end bracket the measured number.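

On the aromatic carbon next to the ring nitrogen, diethylamino in place of dimethylamino gives a 2.5-fold lower number from compound 1 to compound 3 (0.40 log units; beyond the scatter), and a lower number here means stronger inhibition. For the compounds shown here, this position therefore accepts the larger amine group and even gains from it, which the earlier compounds could not show. No measurement shown gives a reason for this step. As far as these compounds go, whether a longer chain on the nitrogen, as in dipropylamino, would extend the gain remains open, and so does the outcome with a ring amine such as pyrrolidine or morpholine.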